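The compounds below may be only part of what the source reports. "The series", "measured", "known", "first", "only" and "open" are said of these compounds alone.

Working notes on the series, with two numbers so far. In a physicochemical assay for solubility, using potentiometric titration (on this read-out higher numbers stand for higher solubility and lower numbers for lower solubility), compound 2 (`Fc1ccc(-c2nc(-c3ccc(-c4ccccc4)cc3)no2)cc1F`) gives 16000 nM and stands lowest of the two, while compound 1 (`Cc1ccnc(-c2noc(-c3ccc(F)c(F)c3)n2)c1`) gives 220000 nM as the higher number, a gap beyond the usual scatter. Going by the values given here, these two compounds differ in more than one place, so no measured single-change step is available as a guide. Compound 3 (`Fc1ccc(-c2nc(-c3ccc(Br)cc3)no2)cc1F`) keeps the rest of compound 2 and carries bromo in place of phenyl on an aromatic carbon, para to a large group. The counted difference is bromo in place of phenyl on an aromatic carbon and nothing else changes. Among the compounds with values here, with no measured precedent for this exchange, the expectation rests only on the room seen above compound 2 at 16000 nM in the series, where compound 1 reaches 220000 nM on a different structure. An upward step is expected in this assay and is estimated as a 2.5-fold higher number from compound 2 to compound 3 (0.40 log units; beyond the scatter) with a size slightly beyond the scatter. For compound 3 the estimated value is 40000 nM within an expected range from 12000 nM to 130000 nM on this read-out.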

Compound 3, solubility: 77000 nM
The estimate for compound 3 lay 1.9-fold (0.28 log units) below the measured number; measured number inside the range.
By their numbers in this assay, from the lowest: compound 2; then compound 3; then compound 1.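

Going by these compounds alone, at the aromatic carbon para to a large group, this is the first single-change step, and it shows that the number in this assay responds to the group held at this place: bromo in place of phenyl gives a 4.8-fold higher number from compound 2 to compound 3 (0.68 log units; beyond the scatter). The counted change is the loss of a six-membered aromatic ring of carbon only and the entry of a single bromine atom, with hydrogen-bond donors, hydrogen-bond acceptors and net charge the same on both sides, so this step separates the exchange from any change in those counts. No independent measurement is available to explain the step, which therefore stands as an observation on this one pair.

From the compounds shown here alone, with a single step at this place, it remains open whether the number follows the size of the group or depends on something particular to phenyl and bromo, and chloro, an amine, a carboxylic acid or a longer chain at the same carbon would help separate these readings. Going by these compounds, it also remains open whether the same exchange would give a step of similar size on a different core, such as that of compound 1.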